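The compounds below may be only part of what the source reports. "The series", "measured", "known", "first", "only" and "open" are said of these compounds alone.

Measured so far in a functional assay on the whole organism (artery, strain albino) with Rattus norvegicus as the target, with a stated time of 15 min, at a dose of 10 mg/kg by the oral route; on this read-out higher numbers stand for more inhibition at the one dose given (going by the name of the read-out) and lower numbers for less inhibition:
compound 1 `CC1=C(C(=O)Nc2ccc(Br)cc2)C(c2ccc(Cl)cc2Cl)N=C(SCc2cccc(Cl)c2)N1` gives 1.5%
compound 2 `CC1=C(C(=O)Nc2ccc(Br)cc2)C(c2ccc(Cl)cc2Cl)N=C(SCc2ccc(Cl)cc2)N1` gives 4.1%

Compound 2 holds the higher of the two numbers, and its nearest neighbour is compound 1, with a number 2.6 percentage points higher from compound 1 to compound 2 (within the scatter). The next compound, compound 3 `CC1=C(C(=O)Nc2ccc(Br)cc2)C(c2ccc(Cl)cc2Cl)N=C(SCc2ccc(F)cc2)N1`, differs from compound 2 by fluoro in place of chloro on an aromatic carbon. Among the measured compounds shown here, the only measured step, 4-chlorophenyl in place of 3-chlorophenyl, stayed within the scatter and concerns where the chloro sits, not its exchange for fluoro; no direct precedent exists. With both measured numbers low, no step beyond the scatter is expected, a number 1.1 percentage points lower from compound 2 to compound 3 (within the scatter). Compound 3 is estimated at 3%, within -6% to 12%.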

Compound 3, a percentage reported as inhibition, in the whole organism at one dose (the size of the read-out at that dose, not a potency): 3.6%
The estimate for compound 3 lay 0.6 percentage points below the measured number; measured number inside the range.
By their numbers in this assay, from the lowest: compounds 1, 3 and 2 (each within the scatter of the next).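

In this assay the exchange of 4-chlorobenzyl for 4-fluorobenzyl, on an aromatic carbon para to a large group, gives a number 0.5 percentage points lower from compound 2 to compound 3 (within the scatter) and so leaves this position without a readable halogen effect. Going from 3-chlorophenyl to 4-fluorophenyl gives a number 2.1 percentage points higher from compound 1 to compound 3 (within the scatter) and likewise separates nothing, so all three compounds remain within the scatter of each other. Nothing measured bears on why these numbers lie together.

Open, from the compounds shown here alone, is whether an amine or a carboxylic acid in place of the halogen would move the number beyond the scatter. Also open, going by these compounds, is whether a longer chain between the sulfur and the aromatic ring would do so.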